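The source may hold more compounds than are shown below. What is called first, only, known or untested is meant among the compounds shown, and "the series" means these compounds.

In a functional assay on the whole organism (Hindlimb, strain albino) with Mus musculus as the target, in the maximal electroshock model, with a stated time of 0.5 h (on this read-out higher numbers stand for an effect only at larger amounts of compound and lower numbers for an effect already at smaller amounts), compound 1 (`Cc1ccc2nc(NC(=O)/C=C/OC3=CC=C3)sc2c1`) gives 505 umol/kg and compound 2 (`O=C(/C=C/OC1=CC=C1)Nc1nc2ccc([N+](=O)[O-])cc2s1`) gives 597 umol/kg. Among the measured compounds shown here, these two values lie within the scatter of each other, so compound 1 stands level with the only other compound measured so far. Compound 3 (`Cc1ccc2nc(NC(=O)/C=C/c3ccc(O)cc3)sc2c1`) has not yet been measured. It keeps the core of compound 1 and differs from it in one place: a group of 7 heavy atoms (6 carbon, 1 oxygen; one six-membered aromatic ring of carbon only) in place of a group of 5 heavy atoms (4 carbon, 1 oxygen; one four-membered non-aromatic ring of carbon only), on a double-bonded chain carbon bound to a double-bonded chain carbon. For the measured compounds named here, the one measured step, a 1.2-fold higher number from compound 1 to compound 2 (0.07 log units; within the scatter), is nitro in place of methyl on an aromatic carbon. That is a different change at a different place, and it stayed within the scatter, so it bears on the new change only indirectly. Going by the values given here, no measured compound carries 4-hydroxyphenyl, and the data give no direction for its effect. The expectation is therefore no shift beyond the scatter in this assay, and the estimated change is a 1.2-fold lower number from compound 1 to compound 3 (0.07 log units; within the scatter). Among the compounds with values here, for compound 3 the expected value is 430 umol/kg, with an estimated range from 170 umol/kg to 1000 umol/kg, kept wide as only two measurements support it.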

Compound 3, dose for half-maximal effect: 271 umol/kg
Beside the measured number, compound 3's estimate is 1.6-fold (0.20 log units) above it; the measured number falls inside the stated range.
By their numbers in this assay, from the lowest: compounds 3, 1 and 2 (each within the scatter of the next, the first and the last beyond it).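

This is the first step shown at the place on a double-bonded chain carbon bound to a double-bonded chain carbon, since the earlier pair differed only on an aromatic carbon. In this assay the exchange of the group with one four-membered non-aromatic ring and 0 hydrogen-bond donors for 4-hydroxyphenyl, with one six-membered aromatic ring and 1 hydrogen-bond donor, gives a 1.9-fold lower number from compound 1 to compound 3 (0.27 log units; within the scatter) and so stays inside the usual scatter, which shows that this position accepts a clearly different group with the core of compound 1 held constant and without a shift that can be told from repeat variation. Nothing at hand explains the size of this step or ties it to any feature of either group.

The compounds shown leave open whether the hydroxyl of 4-hydroxyphenyl contributes at all, which a plain phenyl ring, a 4-methoxyphenyl group or a 4-aminophenyl group at the same place would help to settle. They also leave open how a carboxylic acid or a longer alkyl chain would behave there, and whether a step beyond the scatter can be reached at this position.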